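The source may hold more compounds than are shown below. What is called first, only, known or untested is meant among the compounds shown, and "the series" means these compounds.

Measured compounds in a functional assay on MDA-MB-231 cells (Homo sapiens) for cytotoxicity, read by MTT assay, with a stated time of 48 h; a higher number here means a weaker inhibitor, a lower number a stronger inhibitor:
- compound 1, `CC(C)=CCC/C(C)=C/CC/C(C)=C/CSc1ccccc1C(=O)N1CCC[C@H]1C(=O)OCCCCOc1no[n+]([O-])c1S(=O)(=O)c1ccccc1`, gives 3140 nM
- compound 2, `CCCCOc1no[n+]([O-])c1S(=O)(=O)c1ccccc1`, gives 9870 nM
- compound 3, `CC(C)=CCC/C(C)=C/CC/C(C)=C/CSc1ccccc1C(=O)N1CCC[C@H]1C(=O)OCC#CCOc1no[n+]([O-])c1S(=O)(=O)c1ccccc1`, gives 1070 nM

Compound 2 stands highest of the three numbers in this assay; compound 1 lies nearest, with a lower number beyond the scatter, and compound 3 lies furthest, also beyond the scatter. Compound 1 and compound 3 share everything except the chain between the ester and the aromatic oxygen, and of that pair compound 3 shows the lower number.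

Compound 4, `CC#CCOc1no[n+]([O-])c1S(=O)(=O)c1ccccc1`, is the one open question. It differs from compound 2 in one place: prop-1-yn-1-yl in place of propyl on a saturated chain carbon bound to an oxygen on an aromatic ring. Within the data shown here, no step between two measured compounds maps exactly onto this change, so the expectation rests on compound 2 itself and on what compound 1 and compound 3 show when read side by side. A downward move in this assay is expected for the step of a 2.0-fold lower number from compound 2 to compound 4 (0.30 log units; within the scatter), modest and not far beyond the scatter, since the triple bond in compound 3 goes with the lower number of that pair. For compound 4 the estimated value is 5000 nM, with a plausible range from 2200 nM to 11000 nM.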

Compound 4, half-maximal inhibitory concentration: 6970 nM
Estimate against measurement, compound 4: 1.4-fold (0.14 log units) below; measured number inside the range.
By their numbers in this assay, from the lowest: compound 3; then compound 1; then compounds 4 and 2 (each within the scatter of the next).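

In this assay the exchange of propyl for prop-1-yn-1-yl, on a saturated chain carbon bound to an oxygen on an aromatic ring, reads as a 1.4-fold lower number from compound 2 to compound 4 (0.15 log units; within the scatter), so at this position, on the small compound alone, the triple bond does not separate the pair. The earlier compounds shown here showed a triple bond only in a related chain change within the much larger ester-linked structure, where compound 1 gives 3140 nM and compound 3 gives 1070 nM; those printed values stand further apart, and the new pair does not show the same separation once that larger part is absent. No measurement at hand accounts for this difference between the two settings.

Still open, from the compounds shown here alone, is whether a hexyl chain in place of the butyl chain of compound 2, or an amine carried on that chain, would move the number beyond the scatter in this assay. Also open, going by these compounds, is whether the small pair and the large pair would read the same way on a second cell line.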